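The source may report more compounds than this note shows. Statements on the series, on what has been measured and on what is new or still open speak of the compounds shown alone.

Measured so far in a functional assay on A549 cells (Homo sapiens) for antiproliferative activity, read by MTT assay, with a stated time of 72 h; a lower number here means a stronger inhibitor, a higher number a weaker inhibitor:
compound 1 `O=C(Nc1ccc(CN2CCCCC2)cc1)Nc1ccc2ncnc(Nc3cccc(C(F)(F)F)c3)c2c1`: 1050 nM
compound 2 `Cc1ccc(NC(=O)Nc2ccc3ncnc(Nc4cccc(C(F)(F)F)c4)c3c2)cc1`: 4140 nM

Compound 2 stands with the higher number of the two. Among the measured compounds shown here, the one measured step, a 3.9-fold higher number from compound 1 to compound 2 (0.60 log units; beyond the scatter), separates it from compound 1 and lies beyond the scatter.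

Next comes compound 3 `CCN(CC)c1ccc(NC(=O)Nc2ccc3ncnc(Nc4cccc(C(F)(F)F)c4)c3c2)cc1`. It differs from compound 2 in one place: diethylamino in place of methyl on an aromatic carbon. A nitrogen-bearing group thus enters where compound 2 carries only a methyl, para to a large group.

For the measured compounds named here, only one measured step bears on this, a 3.9-fold higher number from compound 1 to compound 2 (0.60 log units; beyond the scatter), in which a nitrogen-bearing group at that position, piperidin-1-yl on a saturated chain carbon, went with the lower number. Diethylamino is a different group, bound directly to the aromatic carbon rather than through a saturated chain carbon, so the step need not match in size. Still, a modest move to a lower number in this assay is expected, the result likely landing between the two measured compounds. The expected step is a 2.1-fold lower number from compound 2 to compound 3 (0.32 log units; beyond the scatter), giving for compound 3 an estimated 2000 nM with a range of 700 nM to 6000 nM.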

Compound 3, half-maximal inhibitory concentration: 3520 nM
Beside the measured number, compound 3's estimate is 1.8-fold (0.25 log units) below it; the measured number falls inside the stated range.
By their numbers in this assay, from the lowest: compound 1; then compounds 3 and 2 (each within the scatter of the next).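

Working note on the aromatic carbon that carries the large group at the opposite end of the ring: in this assay, diethylamino in place of methyl gives a 1.2-fold lower number from compound 2 to compound 3 (0.07 log units; within the scatter) and so leaves compound 3 and compound 2 indistinguishable, which means that a nitrogen-bearing group at this position does not by itself go with a lower number. The earlier pairing of nitrogen with the lower number now has compound 3 against it, and a 3.4-fold higher number from compound 1 to compound 3 (0.53 log units; beyond the scatter) keeps compound 1 alone at the low end of the three, so among these compounds the lower number is tied to (piperidin-1-yl)methyl specifically and not to nitrogen in general. No supporting measurement is available to explain this difference.

On these data alone, compound 1 and compound 3 differ in both the amine and its attachment, so it remains open whether the saturated chain carbon, the piperidine ring or both go with the lower number. Diethylaminomethyl and piperidin-1-yl bound directly to the aromatic carbon would separate these two features, while a morpholine ring or a carboxylic acid at this position would test whether the amine nitrogen matters at all.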